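A longer saturated chain on compound 3

The source may hold more compounds than are shown below. What is called first, only, known or untested is meant among the compounds shown, and "the series" means these compounds.

compound 1 `COC(=O)C1=CO[C@@H](O[C@@H]2O[C@H](COC(c3ccccc3)(c3ccccc3)c3ccccc3)[C@@H](O)[C@H](O)[C@H]2O)[C@@H]2[C@@H](C)[C@@H](O)C[C@H]12` gives 0.56 ug/mL
compound 2 `COC(=O)C1=CO[C@@H](O[C@@H]2O[C@H](COC(c3ccccc3)(c3ccccc3)c3ccccc3)[C@@H](OC(=O)O)[C@H](OC(C)=O)[C@H]2OC(C)=O)[C@@H]2[C@@H](C)[C@@H](OC(C)=O)C[C@H]12` gives 3.45 ug/mL
compound 3 `CCCCCCCCCCCC(=O)OC[C@H]1O[C@@H](O[C@@H]2OC=C(C(=O)OC)[C@H]3C[C@H](OC(C)=O)[C@H](C)[C@@H]23)[C@H](OC(C)=O)[C@@H](OC(C)=O)[C@@H]1OC(C)=O` gives 0.42 ug/mL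

All three numbers come from a functional assay on Caco-2 cells (Homo sapiens) for cytotoxicity, read by MTT assay, with a stated time of 4 h (a higher number here means a weaker inhibitor, a lower number a stronger inhibitor), and can be compared directly. Compound 3 at 0.42 ug/mL and compound 1 at 0.56 ug/mL sit within the usual scatter of each other, so this measurement cannot tell them apart. Compound 2 at 3.45 ug/mL gives a higher number than compound 3, and that gap lies beyond the scatter.

Compound 4 `CCCCCCCCCCCCCCCC(=O)OC[C@H]1O[C@@H](O[C@@H]2OC=C(C(=O)OC)[C@H]3C[C@H](OC(C)=O)[C@H](C)[C@@H]23)[C@H](OC(C)=O)[C@@H](OC(C)=O)[C@@H]1OC(C)=O` matches compound 3 except at one place, and butyl in place of hydrogen on a saturated chain carbon, ten or more bonds along the chain from a carbonyl carbon is the whole difference: butyl in place of hydrogen on a saturated chain carbon, ten or more bonds along the chain from a carbonyl carbon.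

Going by the values given here, no two measured compounds show this change on its own, so there is no direct guide to its size. The starting point is compound 3 at 0.42 ug/mL in this assay and nothing more. The expected 1.2-fold higher number from compound 3 to compound 4 (0.08 log units; within the scatter) is estimated to stay within the scatter, with no direction that could be told apart. Expected for compound 4 is 0.5 ug/mL as the middle value, within an estimated range from 0.18 ug/mL to 1.4 ug/mL at its ends.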

Compound 4, half-maximal inhibitory concentration: "not active" (no number reported)
For compound 4 the study gives words and no number, and the estimate cannot be compared.
By their numbers in this assay, from the lowest: compounds 3 and 1 (each within the scatter of the next); then compound 2.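

Going by these compounds alone, compound 4 is reported in this assay only in the words "not active", without a number, so no step from compound 3 to compound 4 can be read. No measured evidence bears on this result. The compounds shown leave open how far butyl in place of hydrogen on the chain shifts the half-maximal inhibitory concentration.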